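Extending the ether chain on the shared core by one carbon

The source may hold more compounds than are shown below. What is called first, only, known or untested is meant among the compounds shown, and "the series" means these compounds.

Compound 1 `CCOc1nc(N)nc2c1ncn2/C=C1/CC1(CO)CO` — > 20000 nM in an ADME assay on CCRF-HSB-2 cells (Homo sapiens) for cytotoxicity, with a stated time of 7 days; a lower number here means that less compound is tolerated, a higher number that more compound is tolerated
Compound 2 `CCCCCCCCOc1nc(N)nc2c1ncn2/C=C1/CC1(CO)CO` — > 20000 nM
Compound 3 `Nc1nc(NCc2ccccc2)c2ncn(/C=C3/CC3(CO)CO)c2n1` — > 20000 nM

All three measured compounds return only a limit of the assay rather than a number. Compound 1 stands at that limit in this assay, with > 20000 nM. Compound 2, with the longer ether chain, likewise gives a limit, > 20000 nM. Compound 3, which carries benzylamino on the aromatic carbon, also gives a limit, > 20000 nM. The steps between them therefore cannot be read: a step that the two limits leave unreadable from compound 1 to compound 2, a step that the two limits leave unreadable from compound 1 to compound 3 and a step that the two limits leave unreadable from compound 2 to compound 3. This is summed up by the limit of > 20000 nM in this assay, at which 3 of the 3 values shown sit.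

Compound 4 `CCCOc1nc(N)nc2c1ncn2/C=C1/CC1(CO)CO` differs from compound 1 by methyl in place of hydrogen on a saturated chain carbon, two bonds along the chain from an oxygen on an aromatic ring. The step from compound 1 to compound 2, which extends the same chain much further, gives no readable change, so no step beyond the scatter is expected for this assay; compound 4 is expected to sit at the limit as well, with a step that the limit leaves unreadable from compound 1 to compound 4. The estimate for compound 4 is 40000 nM, between 20000 nM and 200000 nM.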

Compound 4, half-maximal cytotoxic concentration: > 20000 nM
Compound 4: a limit, no number; the forecaster's own chance of this, stated with the estimate: 90%; the middle value is on the limit's open side.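

In this assay compound 4 gives > 20000 nM which is a limit and not a number. Within the data shown here, no step linking compound 4 to compound 1, compound 2 or compound 3 can be read: the limit of > 20000 nM in this assay, at which 4 of the 4 values shown sit. The compounds shown leave open whether any change on the shared core moves the half-maximal cytotoxic concentration at all.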